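A few compounds are considered here, and "the series" means these few. Any claim that something is new, unique, unknown or untested is made for them only; others in the source may bear on it.

Measured so far in a functional assay on the whole organism for inhibition, with Mus musculus as the target; a higher number here means that more compound is needed for the effect, a lower number that less compound is needed:
- compound 1 (`CC1CCSC1=O`): 91 mg/kg
- compound 2 (`CC(C)C1CCSC1=O`): 145 mg/kg

Only these two compounds have been measured, and compound 2 lies within the usual scatter of compound 1, so the pair cannot be ranked. The next compound to be tested is compound 3 (`CC(C)(C)C1CCSC1=O`). It keeps the shared core of compound 2 and differs in one place: methyl in place of hydrogen on a saturated chain carbon bound to two saturated chain carbons and a saturated ring carbon.

Among the compounds with values here, only one measured step bears on this change. Putting isopropyl in place of methyl on a saturated ring carbon gave a 1.6-fold higher number from compound 1 to compound 2 (0.20 log units; within the scatter). That step also added carbon to the group on the core, and it did not move the number beyond the scatter. A single step cannot establish a trend, so it offers only weak guidance. Even so, a further methyl is a small change, and no shift beyond the scatter is expected in this assay. The expected change is a 1.1-fold higher number from compound 2 to compound 3 (0.06 log units; within the scatter), possibly towards a slightly higher number. For compound 3 the estimated value is 165 mg/kg, with an expected range from 85 mg/kg to 320 mg/kg.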

Compound 3, dose for half-maximal effect: 244 mg/kg
Beside the measured number, compound 3's estimate is 1.5-fold (0.17 log units) below it, within the range that was stated.
By their numbers in this assay, from the lowest: compounds 1, 2 and 3 (each within the scatter of the next, the first and the last beyond it).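

In this assay, methyl in place of hydrogen on this saturated chain carbon gave a 1.7-fold higher number from compound 2 to compound 3 (0.23 log units; within the scatter), so this change alone cannot be told apart from the spread of repeated measurements. The result matters more for the short series as a whole: compound 1 at 91 mg/kg and compound 3 at 244 mg/kg lie beyond the usual scatter of each other, so two steps that are each within the scatter add up to a real difference, with more compound needed once the group on the core has grown from methyl to the larger carbon group of compound 3. No measurement shown here explains this difference.

Going by these compounds, all three compounds carry a plain saturated carbon group at this place, so it remains open whether an amine, a hydroxyl or a phenyl ring there would leave the number in this assay where it is or shift it. On these data alone, it also remains open whether a longer chain would raise the number further, since three compounds show only a short run of small carbon groups.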